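The compounds below may be only part of what the source reports. "The series", "measured", "known", "first", "only" and "open" are said of these compounds alone.

Working notes on the dichloroacetanilide series. Three measured members are on record: compound 1 `O=C(Nc1ccccc1)C(Cl)Cl`, compound 2 `Cc1cccc(NC(=O)C(Cl)Cl)c1` and compound 3 `O=C(Nc1cccc(OC(F)(F)F)c1)C(Cl)Cl`. For compound 1 the entry in a functional assay on KB cells (Homo sapiens) for antiproliferative activity, read by MTT assay, with a stated time of 72 h (on this read-out lower numbers stand for stronger inhibition and higher numbers for weaker inhibition), is "not determined" (no result reported), and for compound 2 the entry is "not determined" (no result reported), so no comparison between them is possible. Going by the values given here, compound 3 is therefore the only member of the set with a number: in this assay compound 3 gives 7410 nM, and it stands alone as the reference point for everything that follows, with nothing beside it to rank it against.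

The next member is compound 4 `O=C(Nc1cccc(SC(F)(F)F)c1)C(Cl)Cl`. It differs from compound 3 in one place, ((trifluoromethyl)sulfanyl in place of trifluoromethoxy on an aromatic carbon); the substituent sits on an aromatic carbon of a six-membered aromatic ring of carbon only, meta to a group of 6 heavy atoms. Among the compounds with values here, no measured pair in the set shows what such a swap does in this assay, so the size of the step cannot be read off from the data and has to be estimated. The expectation is a step from compound 3 to compound 4 of a 1.3-fold lower number from compound 3 to compound 4 (0.13 log units; within the scatter), that is, no shift beyond the usual scatter, with the direction left open. On that basis compound 4 is estimated at 5500 nM in this assay, within a range from 1800 nM to 16000 nM.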

Compound 4, half-maximal inhibitory concentration: 4840 nM
Beside the measured number, compound 4's estimate is 1.1-fold (0.06 log units) above it, and the stated range covers the measured number.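

Going by these compounds alone, with only one number on record before, the series now has its first measured pair: in this assay the swap of trifluoromethoxy for (trifluoromethyl)sulfanyl gives a 1.5-fold lower number from compound 3 to compound 4 (0.18 log units; within the scatter) and so leaves the two compounds indistinguishable in this read-out. For this place, on an aromatic carbon meta to a group of 6 heavy atoms, exchanging the oxygen atom for a sulfur atom while the heavy-atom count and the hydrogen-bond donor and acceptor counts stay the same does not move the result beyond the usual scatter. No measured property of either group is on hand to go with this result.

As far as these compounds go, a single step between two groups of equal size says nothing about how far the read-out can move at this place, and what an amine, a carboxylic acid or a longer alkyl chain would do there remains open. Also open, from the compounds shown here alone, is whether the same exchange of trifluoromethoxy for (trifluoromethyl)sulfanyl would stay within the scatter at another carbon of the same ring.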